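The compounds below may be only part of what the source reports. "The series", "measured", "known", "first", "only" and "open" are said of these compounds alone.

Measured so far:
- compound 1, `CC(C)n1cc(-c2ccnc3[nH]c(C4CCNCC4)cc23)ccc1=O`: < 3 uL/min in an ADME assay on microsomes from liver (Homo sapiens) for metabolic stability; a lower number here means slower removal, a higher number faster removal of the compound
- compound 2, `CC(C)Cn1cc(-c2ccnc3[nH]c(C4CCN(CC(=O)N(C)C)CC4)cc23)ccc1=O`: 21 uL/min

Compound 1 gives in this assay only the lower limit (the limit of < 3 uL/min in this assay, at which 1 of the 2 values shown sits), a limit of the assay rather than a number. Among the measured compounds shown here, compound 2 is therefore the only compound in this set with a real number, 21 uL/min; compound 1 and compound 2 differ in more than one place, so their two values are simply set side by side and no step is drawn between them.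

Compound 3, `CN(C)C(=O)CN1CCC(c2cc3c(-c4ccc(=O)n(CCC5CCOCC5)c4)ccnc3[nH]2)CC1`, has not yet been measured. It differs from compound 2 in one place: (oxan-4-yl)methyl in place of isopropyl on a saturated chain carbon bound to an aromatic nitrogen. Nothing measured here speaks to such a change, so compound 3 is expected to stay close to compound 2, with a step of a 1.4-fold lower number from compound 2 to compound 3 (0.15 log units; within the scatter) that lies within the usual scatter. On that basis compound 3 is estimated at 15 uL/min, between 5 uL/min and 40 uL/min.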

Compound 3, intrinsic clearance in a liver preparation (reported as CLH), per the amount of preparation that the assay uses: 19 uL/min
The estimate for compound 3 lay 1.3-fold (0.10 log units) below the measured number, and the stated range covers the measured number.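

In this assay, among the compounds shown here, setting (oxan-4-yl)methyl in place of isopropyl on a saturated chain carbon bound to an aromatic nitrogen gives a 1.1-fold lower number from compound 2 to compound 3 (0.04 log units; within the scatter), the first step that can be read at this position. The two compounds therefore read alike, even though the entering group brings a six-membered non-aromatic ring and an oxygen that the leaving group lacks. No measurement shown accounts for this result.

A single step cannot separate the contribution of the ring from that of its oxygen, so a cyclohexylmethyl group, its all-carbon counterpart, would be the informative comparison. Going by these compounds, it also remains open whether this place would tolerate a group carrying an amine or a carboxylic acid as it does the (oxan-4-yl)methyl group.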